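A few compounds are considered here, and "the series" means these few. Any claim that something is new, unique, unknown or untested is made for them only; others in the source may bear on it.

Working notes on the dithiocarbamate-linked anilide series.

Compound 1 `CCN(Cc1ccncc1)C(=S)SCc1ccc(C(=O)Nc2ccccc2N)cc1` carries an ethyl group and a pyridylmethyl group on the thiocarbamoyl nitrogen. In a functional assay on MGC-803 cells (Homo sapiens) for antiproliferative activity, read by CCK-8 assay, with a stated time of 72 h, tested at 8 uM (a lower number here means a weaker effect, a higher number a stronger effect of the compound at the concentration tested), compound 1 gives 85.2%. Compound 2 `Nc1ccccc1NC(=O)c1ccc(CSC(=S)N2CCN(Cc3ccccc3)CC2)cc1` replaces that open-chain amine with a ring amine bearing a benzyl group; in this assay compound 2 gives 19.7%. Compound 2 stands lowest of the two numbers available, and the gap to compound 1 lies beyond the usual scatter of this assay.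

Compound 3 `CN1CCN(C(=S)SCc2ccc(C(=O)Nc3ccccc3N)cc2)CC1` is the next member, not yet tested. Relative to compound 2 the change is hydrogen in place of phenyl on a saturated chain carbon bound to an amine nitrogen in a ring. Among the compounds with values here, no measured pair shows this benzyl-to-methyl change, so its effect has to be gauged from compound 2 alone. The change is expected to move the read-out of this assay only modestly, if at all, the step of a number 5.3 percentage points higher from compound 2 to compound 3 (within the scatter) being expected to stay close to the scatter rather than to restore the level of compound 1. Compound 3 is therefore expected to give 25%, within a range from 5% to 55%.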

Compound 3, a percentage reported as inhibition, at one concentration (the size of the read-out at that concentration, not a potency): 84.4%
For compound 3 the middle estimate is 59.4 percentage points below the measured one, outside the stated range (above it).
By their numbers in this assay, from the lowest: compound 2; then compounds 3 and 1 (each within the scatter of the next).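

The benzyl-to-methyl change on the ring amine is a large step in this assay (a number 64.7 percentage points higher from compound 2 to compound 3 (beyond the scatter)), so the group at this place, on a saturated chain carbon bound to an amine nitrogen in a ring, can decide the read-out, which the earlier pair of compounds could not show, since they differed in the whole amine. The ring amine as such does not go with the low number: with 4-methylpiperazin-1-yl in place of ethyl((pyridin-4-yl)methyl)amino on a thiocarbonyl carbon, the step stays within the scatter (a number 0.8 percentage points lower from compound 1 to compound 3 (within the scatter)), and among these compounds only the benzyl-bearing compound 2 stands apart. Nothing on hand explains why the phenyl in compound 2 goes with so large a step.

The compounds shown leave open how the read-out responds to other groups on the ring nitrogen, such as a plain hydrogen, an ethyl, a longer chain ending in phenyl or a chain ending in a carboxylic acid. They also leave open whether the two high numbers would stay level at other concentrations, as each is a read-out at a single concentration and not a potency.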